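The compounds below may be only part of what the source reports. "The series", "measured", "known", "first", "only" and "open" are said of these compounds alone.

Compound 1 `C=CC1=C(C(=O)NCc2ccccc2)C(c2ccc(OC)c(OC)c2)OC1`: in a functional assay on A549 cells (Homo sapiens) for cytotoxicity, read by MTT assay, with a stated time of 24 h (a higher number here means a weaker inhibitor, a lower number a stronger inhibitor), compound 1 gives > 100000 nM, which is a limit of the assay and not a number.
Compound 2 `C=CC1=C(C(=O)O)C(c2ccc(F)cc2)OC1`: compound 2 gives > 100000 nM, again a limit of the assay.
Compound 3 `C=CC1=C(C(=O)O)C(c2ccc(OC)cc2)OC1`: compound 3 gives > 100000 nM, again a limit of the assay.

Compound 2 therefore stands nowhere on a scale of numbers: it sits at the limit, as do all three values shown, (the limit of > 100000 nM in this assay, at which 3 of the 3 values shown sit). The new compound 4 `C=CC1=C(C(=O)NCC(C)C)C(c2ccc(F)cc2)OC1` differs from compound 2 by isobutylamino in place of hydroxy on a carbonyl carbon. For the measured compounds named here, only one measured step exists, a step that the two limits leave unreadable from compound 2 to compound 3, and it cannot be read because both of its ends sit at the limit (the limit of > 100000 nM in this assay, at which 3 of the 3 values shown sit). Going by the values given here, no measured step touches the carbonyl carbon at all; compound 1, which also carries an amide there, shows only the same limit. Nothing among these data points to a step in either direction. Compound 4 is thus expected to give 150000 nM, within a range of 50000 nM to 500000 nM, and most probably again only a limit. The step this estimate implies, a step that the limit leaves unreadable from compound 2 to compound 4, is expected to stay within the scatter.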

Compound 4, half-maximal inhibitory concentration: > 100000 nM
Compound 4 ended at the assay's limit; the forecaster's own chance of this, stated with the estimate: 80%; the middle value is on the limit's open side.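

No step can be read from compound 2 to compound 4, because both compounds sit at a limit and not at a number: the limit of > 100000 nM in this assay, at which 4 of the 4 values shown sit.

The compounds shown leave open whether isobutylamino in place of hydroxy on the carbonyl carbon changes anything in this assay, since none of them gives a number there.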